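Removing the Methoxy Group from a Benzyl Ring

The source may report more compounds than this note shows. Statements on the series, on what has been measured and on what is new or still open speak of the compounds shown alone.

Three compounds share one core and differ only in the ring carried on a saturated chain carbon bound to an amine nitrogen. In a functional assay on ASPC1 cells (Homo sapiens) for inhibition, read by MTT assay, with a stated time of 72 h (on this read-out lower numbers stand for stronger inhibition of growth and higher numbers for weaker inhibition of growth), compound 1 `O=S(=O)(NCCCNCc1cccc(Cl)c1)c1cc(C(F)(F)F)cc(C(F)(F)F)c1` gives 5900 nM, compound 2 `O=S(=O)(NCCCNCc1ccc(C(F)(F)F)cc1)c1cc(C(F)(F)F)cc(C(F)(F)F)c1` gives 2000 nM, and compound 3 `COc1ccccc1CNCCCNS(=O)(=O)c1cc(C(F)(F)F)cc(C(F)(F)F)c1` gives 4600 nM. Compound 3 thus stands second highest of the three, close to compound 1 and furthest from compound 2. Compound 4 `O=S(=O)(NCCCNCc1ccccc1)c1cc(C(F)(F)F)cc(C(F)(F)F)c1` differs from compound 3 by hydrogen in place of methoxy on an aromatic carbon. Going by the values given here, no measured step removes a group outright; the ring swaps a 3.0-fold lower number from compound 1 to compound 2 (0.47 log units; beyond the scatter), a 1.3-fold lower number from compound 1 to compound 3 (0.11 log units; within the scatter) and a 2.3-fold higher number from compound 2 to compound 3 (0.36 log units; beyond the scatter) were at most modest. A step of similar size, or none beyond the scatter, is therefore expected, a 1.1-fold higher number from compound 3 to compound 4 (0.04 log units; within the scatter). Compound 4 is estimated at 5000 nM, expected between 2000 nM and 12000 nM.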

Compound 4, concentration for 50% growth inhibition: 13000 nM
The estimate for compound 4 lay 2.6-fold (0.41 log units) below the measured number; measured number above the stated range.
By their numbers in this assay, from the lowest: compound 2; then compounds 3 and 1 (each within the scatter of the next); then compound 4.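

In this assay the unsubstituted ring of compound 4 gives the weakest growth inhibition of the four, so here each of the three ring groups goes with stronger inhibition than hydrogen. Hydrogen in place of methoxy gives a 2.8-fold higher number from compound 3 to compound 4 (0.45 log units; beyond the scatter), in place of trifluoromethyl a 6.5-fold higher number from compound 2 to compound 4 (0.81 log units; beyond the scatter), and in place of chloro a 2.2-fold higher number from compound 1 to compound 4 (0.34 log units; beyond the scatter). No measurement shown here explains this. Still open, from the compounds shown here alone, is whether a nitrile or an amine on the ring would also beat hydrogen, and whether methoxy, chloro or trifluoromethyl would give the same numbers elsewhere on the ring.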